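This account rests on a few compounds, and the source may have more. Where it says the series, first, only, none or still open, it means among the compounds named here.

In a functional assay on H157 cells (Homo sapiens) for antiproliferative activity, read by trypan blue exclusion (a lower number here means a stronger inhibitor, a higher number a weaker inhibitor), compound 3 `COc1ccc(CS(=O)(=O)/C=C/c2c(OC)cc(OC)cc2OC)cc1` gives 30 nM. For compound 1 `COc1ccc(CS(=O)(=O)/C=C/c2ccc(OC)cc2OC)cc1` this assay reports only a limit, > 20000 nM. For compound 2 `COc1ccc(CS(=O)(=O)/C=C/c2cc(OC)cc(OC)c2)cc1` this assay likewise reports only a limit, > 20000 nM, and the difference between the core of compound 2 and the core of compound 1 is not broken down here. From compound 1 to compound 3 the change is methoxy in place of hydrogen on an aromatic carbon, and it gave an at least 660-fold lower number from compound 1 to compound 3 (2.82 log units; beyond the scatter). Compound 4 `COc1ccc(CS(=O)(=O)/C=C/c2cc(OC)c(OC)c(OC)c2)cc1` is not yet measured; from compound 2 to compound 4 the change is methoxy in place of hydrogen on an aromatic carbon, the same kind of change, but here the entering methoxy is ortho to two methoxy groups and para to a large group rather than ortho to a large group and meta to two methoxy groups. Resting on the step from compound 1 to compound 3 an at least 660-fold lower number from compound 1 to compound 3 (2.82 log units; beyond the scatter), the step from compound 2 to compound 4 is expected to be an at least 200-fold lower number from compound 2 to compound 4 (2.30 log units; beyond the scatter). Compound 4 is therefore estimated at 100 nM, between 15 nM and 2000 nM.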

Compound 4, half-maximal inhibitory concentration: > 20000 nM
Compound 4: no number, only a limit; the forecaster's own chance of this, stated with the estimate: 20%; middle value at least 200-fold (2.30 log units) from the limit.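

Compound 2 and compound 4 both give only a limit, not a number, so the step between them cannot be read: the limit of > 20000 nM in this assay, at which 3 of the 4 values shown sit.

The compounds shown leave open whether this added methoxy changes the activity of compound 2 at all.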